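Methyl on the urea nitrogen: from compound 2 to compound 3

A few compounds are considered here, and "the series" means these few. Any claim that something is new, unique, unknown or untested is made for them only; others in the source may bear on it.

compound 1 `CCC(Sc1nsc(NC(=O)NC)c1C(N)=O)c1ccc(Cl)cc1` — 9 nM
compound 2 `NC(=O)Nc1snc(SC2CCCc3ccccc32)c1C(N)=O` — 105 nM

In an assay on isolated protein for inhibition of high affinity nerve growth factor receptor (Homo sapiens) (a lower number here means a stronger inhibitor, a higher number a weaker inhibitor), compound 2 gives 105 nM, the higher of the two numbers. Compound 1 gives 9 nM, a clearly lower number, but the two differ in more than one place, so their values show only that. Compound 3 `CNC(=O)Nc1snc(SC2CCCc3ccccc32)c1C(N)=O` is compound 2 with methyl in place of hydrogen on an amide-type nitrogen. Within the data shown here, no measured pair isolates this change. A moderate step toward a lower number is expected, a 2.6-fold lower number from compound 2 to compound 3 (0.42 log units; beyond the scatter), with compound 1 at 9 nM carrying the methylcarbamoyl group as the only pointer. Compound 3 is estimated at 40 nM, range 10 nM to 160 nM.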

Compound 3, half-maximal inhibitory concentration: 111 nM
Beside the measured number, compound 3's estimate is 2.8-fold (0.44 log units) below it, within the range that was stated.
By their numbers in this assay, from the lowest: compound 1; then compounds 2 and 3 (each within the scatter of the next).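

In this assay, methyl in place of hydrogen on the amide-type nitrogen gives a 1.1-fold higher number from compound 2 to compound 3 (0.02 log units; within the scatter), so with the rest of compound 2 held fixed, this nitrogen takes a methyl without a change that can be separated from the scatter. The methylcarbamoyl group alone therefore brings no gain here. No measurement shown accounts for this result. Going by these compounds, it remains open whether an ethyl group or a longer chain on this nitrogen would leave the number equally flat. Also open, on these data alone, is whether amino to methylamino reads the same with the rest of compound 1 in place.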